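The compounds below may be only part of what the source reports. "The series", "measured", "known", "first", "only" and "open" are said of these compounds alone.

Measured compounds:
Compound 1, `C[Se]/C(=N\C(=O)c1ccco1)NC(=O)c1ccco1`, gives 40200 nM in an ADME assay on MCF-10A cells (Homo sapiens) for cytotoxicity, read by MTT assay, with a stated time of 72 h; on this read-out higher numbers stand for weaker inhibition of growth and lower numbers for stronger inhibition of growth.
Compound 2, `C[Se]/C(=N\C(=O)c1sccc1Cl)NC(=O)c1sccc1Cl`, gives 5490 nM in this assay.
Compound 3, `CS/C(=N\C(=O)c1csc([N+](=O)[O-])c1)NC(=O)c1csc([N+](=O)[O-])c1`, gives 21400 nM in this assay.

Among these three numbers compound 3 stands second highest. Its nearest neighbour is compound 1, whose number is higher by an amount that lies within the scatter, so the two cannot be told apart. Its furthest neighbour is compound 2, whose number is lower by an amount beyond the scatter, so compound 2 inhibits growth more strongly than compound 3.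

Compound 4, `O=C(/N=C(/NC(=O)c1csc([N+](=O)[O-])c1)[Se]Cc1ccccc1)c1csc([N+](=O)[O-])c1`, has not yet been measured in this assay. It differs from compound 3 in one place: a group of 8 heavy atoms (7 carbon, 1 selenium; one six-membered aromatic ring of carbon only) in place of a group of 2 heavy atoms (1 carbon, 1 sulfur; no ring), on a carbon with a double bond to nitrogen. Among the compounds with values here, no pair of measured compounds differs in exactly this way, so no directly comparable step is available. The expected step of a 2.4-fold lower number from compound 3 to compound 4 (0.38 log units; beyond the scatter) is a modest move toward a lower number, that is toward stronger inhibition of growth, though it may not clearly exceed the scatter. Compound 4 is therefore estimated at 9000 nM in this assay, with a range from 2500 nM to 30000 nM.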

Compound 4, concentration for total growth inhibition: 54100 nM
The estimate for compound 4 lay 6.0-fold (0.78 log units) below the measured number, and the stated range ends below it.
By their numbers in this assay, from the lowest: compound 2; then compounds 3, 1 and 4 (each within the scatter of the next, the first and the last beyond it).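

In this assay, replacing methylsulfanyl with the larger selenium-containing group and its six-membered aromatic ring, on the carbon with a double bond to nitrogen, gives a 2.5-fold higher number from compound 3 to compound 4 (0.40 log units; beyond the scatter) and so a modest move toward weaker inhibition of growth. Within the data shown here, this is the first view of a single change at this position, and here the larger group with its ring brings no gain in growth inhibition. Nothing measured here bears on why the number rose.

The step changes sulfur to selenium and adds the ring at the same time, so the compounds shown leave open how much of it belongs to each change. A methyl group on selenium would help to separate the two, while an amine or a longer chain on this carbon remains an open comparison.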